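Chloro added to the pendant phenyl of compound 2

This account rests on a few compounds, and the source may have more. Where it says the series, first, only, none or still open, it means among the compounds named here.

Compound 1 `Cc1cc(S(=O)(=O)Nc2nc3ccccc3c(=O)n2N)c(S)cc1Cl` in a functional assay on EKVX cells (Homo sapiens) for inhibition (a lower number here means a stronger inhibitor of growth, a higher number a weaker inhibitor of growth), gives 14800 nM. Compound 2 `Cc1cc(S(=O)(=O)Nc2nc3cc(-c4ccccc4)sc3c(=O)n2Cc2ccccc2)c(S)cc1Cl` carries a benzyl and a phenyl on its core instead. For compound 2 this assay reports only a limit, > 100000 nM, not a number. Of the two values shown, compound 2 is the one that sits at the limit of > 100000 nM in this assay, at which 1 of the 2 values shown sits; compound 1 alone has a measured number. Compound 3 `Cc1cc(S(=O)(=O)Nc2nc3cc(-c4ccc(Cl)cc4)sc3c(=O)n2Cc2ccccc2)c(S)cc1Cl` differs from compound 2 by chloro in place of hydrogen on an aromatic carbon. Among the measured compounds shown here, no measured step of this kind exists, so no direction can be read from the data; the expectation is a step from compound 2 to compound 3 of a number no higher from compound 2 to compound 3 (the limit leaves the size open), none beyond the scatter. Compound 3 is therefore estimated at 100000 nM in this assay, with a range from 30000 nM to 300000 nM, and most likely it will again be reported only as a limit.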

Compound 3, concentration for 50% growth inhibition: > 100000 nM
Compound 3 gave a limit, no number; the forecaster's own chance of this, stated with the estimate: 75%; the middle value lies on the limit itself.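

No new step can be read between compound 2 and compound 3 in this assay, because both are reported only as limits: the limit of > 100000 nM in this assay, at which 2 of the 3 values shown sit.

Going by these compounds, whether the change from phenyl to 4-chlorophenyl shifts growth inhibition in this assay at all, and in which direction, remains open.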